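A para-methoxy on the phenyl of compound 1

The source may hold more compounds than are shown below. What is called first, only, known or untested is meant among the compounds shown, and "the series" means these compounds.

Compound 1 `COc1ccccc1N1CCN(C(=O)CCc2c(-c3ccccc3)[nH]c3ccc(C)cc23)CC1`, 6.1 nM
Compound 2 `COc1ccccc1-c1[nH]c2ccc(C)cc2c1CCC(=O)N1CCN(c2ccccc2OC)CC1`, 82 nM

In an assay on CHO cells for displacement of a labelled ligand from Substance-P receptor (Homo sapiens) (on this read-out higher numbers stand for weaker inhibition and lower numbers for stronger inhibition), compound 1 gives 6.1 nM, the lowest of the two numbers, with compound 2 giving 82 nM. Compound 3 `COc1ccc(-c2[nH]c3ccc(C)cc3c2CCC(=O)N2CCN(c3ccccc3OC)CC2)cc1` differs from compound 1 by methoxy in place of hydrogen on an aromatic carbon. Within the data shown here, the one measured step, a 13-fold higher number from compound 1 to compound 2 (1.13 log units; beyond the scatter), placed the same group elsewhere on the same phenyl and was large. The same group at a different position is therefore expected to weaken binding too, though perhaps less: the step of a 3.3-fold higher number from compound 1 to compound 3 (0.52 log units; beyond the scatter) is expected. Compound 3 is estimated at 20 nM, within 6 nM to 70 nM.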

Compound 3, half-maximal inhibitory concentration: 1.5 nM
Compound 3: the middle estimate sits 13-fold (1.12 log units) above what was measured, outside the stated range (below it).
By their numbers in this assay, from the lowest: compound 3; then compound 1; then compound 2.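

On this phenyl the effect of methoxy depends on where it sits: para to a large group, the change gives a 4.1-fold lower number from compound 1 to compound 3 (0.61 log units; beyond the scatter), opposite in direction to the earlier step. Shifting the group to that place from the one it holds in compound 2 gives the largest of the three steps, a 55-fold lower number from compound 2 to compound 3 (1.74 log units; beyond the scatter). No measurement at hand accounts for this dependence on place. Whether the lower number is specific to methoxy stays open: the compounds shown do not tell how a hydroxyl or an ethoxy at the same place would read.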